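The source may hold more compounds than are shown below. What is called first, only, known or untested is meant among the compounds shown, and "the series" means these compounds.

Three members of the series have been tested so far in a functional assay on HL-60 cells (Homo sapiens) for inhibition, read by CCK-8 assay, with a stated time of 48 h; a lower number here means a stronger inhibitor, a higher number a weaker inhibitor. Compound 1 `O=[N+]([O-])c1ccc(NC(=S)NCCNS(=O)(=O)c2ccc(-c3ccccc3O[C@H]3CC[C@@H](O)CC3)s2)cc1` reaches only the limit of the assay, > 50000 nM. Compound 2 `COc1cccc(NC(=S)NCCNS(=O)(=O)c2ccc(-c3ccccc3Oc3ccc([N+](=O)[O-])cc3)s2)c1` likewise returns only a limit, > 50000 nM. Compound 3 `O=S(=O)(NCCNC(=S)Nc1cccc(Cl)c1)c1ccc(-c2ccccc2OCc2ccccc2)s1` stands at the same limit, > 50000 nM. None of the three values is a number; all sit at the limit of > 50000 nM in this assay, at which 3 of the 3 values shown sit. Compound 4 `O=C(NCCNS(=O)(=O)c1ccc(-c2ccccc2OCc2ccccc2)s1)Nc1cc(Cl)cc(Cl)c1` has not yet been measured in this assay. Relative to compound 3 it carries a group of 11 heavy atoms (7 carbon, 1 nitrogen, 1 oxygen, 2 chlorine; one six-membered aromatic ring of carbon only) in place of a group of 10 heavy atoms (7 carbon, 1 nitrogen, 1 sulfur, 1 chlorine; one six-membered aromatic ring of carbon only), on an amine nitrogen. Among the compounds with values here, no measured pair differs in one place, so no step size is on record for this assay, and with every value so far a limit, nothing points to an effect beyond the scatter in either direction. Compound 4 is therefore expected to remain at the limit as well, the estimate being 70000 nM with a range from 20000 nM to 300000 nM, meaning a step that the limit leaves unreadable from compound 3 to compound 4 that is expected to be none beyond the scatter.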

Compound 4, half-maximal inhibitory concentration: 11700 nM
For compound 4 the middle estimate is 6.0-fold (0.78 log units) above the measured one; the whole stated range lies above it.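

In this assay, as far as these compounds go, the group on the amine nitrogen proves able to shift the read-out, with an at least 4.2-fold lower number from compound 3 to compound 4 (0.63 log units; beyond the scatter), and the size of that step stays open-ended since compound 3 holds only a limit. The entering (3,5-dichlorophenyl)carbamoyl brings oxygen for sulfur and a second chlorine in a single change, so the two stay unseparated. Within the data shown here, compound 4 is the only member so far with a number rather than a limit: the limit of > 50000 nM in this assay, at which 3 of the 4 values shown sit.

Which of the two differences carries the step remains open. Also open, from the compounds shown here alone, is how a pyridine ring or a carboxylic acid on this amine nitrogen would read.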